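Inverting two ring stereocentres of compound 2

This account rests on a few compounds, and the source may have more. Where it says the series, first, only, none or still open, it means among the compounds named here.

Measured in a functional assay on a cell-free system (plasma, Homo sapiens), with a stated time of 3 min; a higher number here means a weaker inhibitor, a lower number a stronger inhibitor:
- Compound 1 `CCCC[C@@H](O)C(=O)N1C[C@H]2C[C@H]2[C@H]1C(=O)NCc1cc(Cl)ccc1-n1cnnn1`: 750 nM
- Compound 2 `O=C(NCc1cc(Cl)ccc1-n1cnnn1)[C@@H]1[C@H]2C[C@H]2CN1C(=O)[C@H](O)Cc1ccccc1`: 1200 nM

Compound 2 stands at 1200 nM, within the scatter of compound 1 at 750 nM. Compound 3 `O=C(NCc1cc(Cl)ccc1-n1cnnn1)[C@@H]1[C@@H]2C[C@@H]2CN1C(=O)[C@H](O)Cc1ccccc1` is a stereoisomer of compound 2: the two compounds have the same atoms and bonds and differ only in configuration as drawn: 2 of 4 stereo elements differ; a stereocentre at a saturated ring carbon is drawn S in compound 2 and R in compound 3; a stereocentre at a saturated ring carbon is drawn R in compound 2 and S in compound 3. Within the data shown here, no measured pair shows the effect of such a change. A moderate move to a higher number in this assay, meaning a weaker inhibitor, is expected, with low confidence in its direction. The expected change is a 1.8-fold higher number from compound 2 to compound 3 (0.26 log units; within the scatter). The estimate for compound 3 is 2200 nM, with an expected range of 450 nM to 11000 nM.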

Compound 3, half-maximal inhibitory concentration: 970 nM
Compound 3: middle estimate off by 2.3-fold (0.36 log units), on the high side; measured number inside the range.
By their numbers in this assay, from the lowest: compounds 1, 3 and 2 (each within the scatter of the next).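

In this assay, among these compounds, inverting the two saturated ring carbons gives a 1.2-fold lower number from compound 2 to compound 3 (0.09 log units; within the scatter), the first reading of a configuration change, and it shows no separable effect of that change: the fact that compounds 2 and 3 differ only in the configuration as drawn. With the ring configuration of compound 3 held, phenyl in place of propyl gives a 1.3-fold higher number from compound 1 to compound 3 (0.11 log units; within the scatter), so this side-chain change is also not separable from the scatter.

Open, from the compounds shown here alone, is whether a longer chain or an amine in place of the phenyl would move the number beyond the scatter. Going by these compounds, the effect of inverting the remaining stereocentres is also open.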